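Moving fluorine around a benzyl ring on a shared core

The source may report more compounds than this note shows. Statements on the series, on what has been measured and on what is new or still open speak of the compounds shown alone.

Measured so far:
Compound 1 `Cc1ccc(/C=C2\CN(C(=S)SCc3cn(Cc4ccccc4F)nn3)C/C(=C\c3ccc(C)cc3)C2=O)cc1`: 28400 nM
Compound 2 `Cc1ccc(/C=C2\CN(Cc3cn(Cc4ccccc4Cl)nn3)C/C(=C\c3ccc(C)cc3)C2=O)cc1`: 23200 nM

Of the compounds shown here, two have been tested in a functional assay on 4T1 cells (Mus musculus) for cytotoxicity, read by MTT assay, with a stated time of 24 h; on this read-out higher numbers stand for weaker inhibition and lower numbers for stronger inhibition. Compound 1 gives 28400 nM. Compound 2 gives 23200 nM. Among the measured compounds shown here, the two numbers lie within the usual scatter of each other, so nothing can be said about which of the two is the more active, and no step between them is counted here, since they differ from each other in more than one place.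

Compound 3 `Cc1ccc(/C=C2\CN(C(=S)SCc3cn(Cc4ccc(F)cc4)nn3)C/C(=C\c3ccc(C)cc3)C2=O)cc1` has not yet been measured. It differs from compound 1 in a single place, with the same atoms joined differently: 4-fluorophenyl in place of 2-fluorophenyl on a saturated chain carbon bound to an aromatic nitrogen. The fluorine simply moves to another position on the same ring, and the rest of compound 1 is kept.

With no comparable change measured in this series, there is no basis for expecting a step beyond the scatter. The step from compound 1 to compound 3 is therefore expected to be small, a 1.1-fold lower number from compound 1 to compound 3 (0.04 log units; within the scatter), in no particular direction. Compound 3 is estimated at 26000 nM, with a range from 10000 nM to 70000 nM.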

Compound 3, half-maximal inhibitory concentration: 29300 nM
Compound 3: middle estimate off by 1.1-fold (0.05 log units), on the low side; the range from low to high includes it.
By their numbers in this assay, from the lowest: compounds 2, 1 and 3 (each within the scatter of the next).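

In this assay, among the compounds shown here, 4-fluorophenyl in place of 2-fluorophenyl on a saturated chain carbon bound to an aromatic nitrogen gives a 1.0-fold higher number from compound 1 to compound 3 (0.01 log units; within the scatter) as the first comparison between compounds that differ in one place. This change of fluorine position therefore leaves the read-out within the scatter, which compound 1 and compound 2 could not show, as they differ in more than one place. All three numbers remain of one order, so this position has so far given no sign of separating the compounds, and no outside measurement bears on this result.

Still open, as far as these compounds go, is whether a different group on this benzyl ring, such as an amine or a carboxylic acid, or a longer chain in place of the benzyl unit, would give a step beyond the scatter. Also open are the separate contributions of the chlorine in compound 2 and of its different link to the shared core, since the compounds shown do not change either feature alone.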